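This account rests on a few compounds, and the source may have more. Where it says the series, first, only, none or still open, it means among the compounds named here.

Measured so far:
- compound 1, `CC(=O)Nc1n[nH]c2cc(-c3cn([C@@H]4CN[C@H](C(=O)Nc5ccc(Cl)cc5Cl)C4)nn3)ccc12`: 1230 nM
- compound 2, `CC(=O)Nc1n[nH]c2cc(-c3cn([C@@H]4CN[C@H](C(=O)Nc5ccc(Br)cc5)C4)nn3)ccc12`: 1000 nM
- compound 3, `O=C(Nc1nc2ccc(-c3cn([C@@H]4CN[C@H](C(=O)Nc5ccc(Cl)cc5Cl)C4)nn3)nc2s1)C1CC1`: 2440 nM

All three were run in a functional assay on K562/Adr cells (Homo sapiens) for inhibition, read by MTT assay, with a stated time of 48 h; a higher number here means a weaker inhibitor, a lower number a stronger inhibitor. Compound 1 and compound 2 share one core and differ only in the aryl amide: 4-bromophenyl in place of 2,4-dichlorophenyl on an amide-type nitrogen. That change gave a 1.2-fold lower number from compound 1 to compound 2 (0.09 log units; within the scatter), a step that does not rise out of the scatter. Compound 3 carries a different core with a cyclopropanecarboxamide in place of the acetamide; the difference between the two cores is not broken down here. Against compound 1 the value of compound 3 lies within the scatter, while against compound 2 the gap is beyond it, so compound 3 sits at the weak end of the three without being clearly separated from compound 1.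

Compound 4, `O=C(Nc1nc2ccc(-c3cn([C@@H]4CN[C@H](C(=O)Nc5ccc(Br)cc5)C4)nn3)nc2s1)C1CC1`, is not yet measured. It relates to compound 3 as compound 2 relates to compound 1: 4-bromophenyl in place of 2,4-dichlorophenyl on an amide-type nitrogen, the same change at the same place. Because the earlier instance gave a 1.2-fold lower number from compound 1 to compound 2 (0.09 log units; within the scatter), the step from compound 3 to compound 4 is expected to be small, a 1.2-fold lower number from compound 3 to compound 4 (0.09 log units; within the scatter). On this basis compound 4 is estimated at 2000 nM, with a likely range from 1000 nM to 4500 nM.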

Compound 4, half-maximal inhibitory concentration: 48300 nM
The estimate for compound 4 lay 24-fold (1.38 log units) below the measured number; measured number above the stated range.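

In this assay, 4-bromophenyl in place of 2,4-dichlorophenyl on the amide-type nitrogen gives a 20-fold higher number from compound 3 to compound 4 (1.30 log units; beyond the scatter), so the change is far from neutral on the core of compound 3. The change does not carry over unaltered between these two cores, and its size on the core of compound 1 is no guide to its size on the core of compound 3: the same change on two cores in this assay, a 1.2-fold lower number (0.09 log units; within the scatter) from compound 1 to compound 2 and a 20-fold higher number (1.30 log units; beyond the scatter) from compound 3 to compound 4, 24-fold (1.39 log units) apart, beyond the scatter of two such steps. Going by these compounds alone, this does not show which structural feature sets the two steps apart, as the two pairs differ both in the core and in the acetamide or cyclopropanecarboxamide it carries, and only one pair per core is at hand.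

Still open, from the compounds shown here alone, is whether the large step belongs to the core of compound 3 or to its cyclopropanecarboxamide, a question that an acetamide on that core would help to settle. Also open, going by these compounds, is how an unsubstituted phenyl or a pyridyl on the amide-type nitrogen would read on either core.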